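The compounds below may be only part of what the source reports. "The series", "measured", "known", "first", "only" and "open" are said of these compounds alone.

Working notes on the series. All three measured compounds share one core and differ only in the amide side chain. In a functional assay on CHO cells for agonist activity at G-protein coupled receptor 52 (Homo sapiens), read by AlphaScreen and cAMP accumulation, with a stated time of 30 min (a higher number here means a larger maximal response, a lower number a smaller maximal response), compound 1 `O=C(NCCO)c1cccc(-c2cccc3cc(Cc4cccc(C(F)(F)F)c4)sc23)c1` gives 79.6%, compound 2 `NC(=O)CNC(=O)c1cccc(-c2cccc3cc(Cc4cccc(C(F)(F)F)c4)sc23)c1` gives 102%, and compound 3 `COCCNC(=O)c1cccc(-c2cccc3cc(Cc4cccc(C(F)(F)F)c4)sc23)c1` gives 85%. Among these, compound 3 sits close to compound 1, the two lying within the scatter of each other (a number 5.4 percentage points higher from compound 1 to compound 3 (within the scatter)), while it falls short of compound 2 by a modest step beyond the scatter (a number 17 percentage points lower from compound 2 to compound 3 (beyond the scatter)). The one clear movement in the set is the carbamoyl in place of hydroxymethyl step, a number 22.4 percentage points higher from compound 1 to compound 2 (beyond the scatter).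

Compound 4 `COCCNC(=O)c1cccc(-c2cccc3cc(Cc4cc(F)cc(Cl)c4)sc23)c1` keeps the methoxyethyl amide of compound 3 and changes the other end of the molecule: 3-chloro-5-fluorophenyl in place of 3-(trifluoromethyl)phenyl on a saturated chain carbon bound to an aromatic carbon. Going by the values given here, none of the measured steps touches this part of the structure; all three concern the amide side chain, so there is no direct precedent in the data for this change. The maximal response in this assay has so far stayed within a fairly narrow band, and in the absence of any step on the benzyl aryl group a change beyond the scatter is not expected. The estimate for compound 4 is 85%, with a range of 65% to 102%, corresponding to an expected step of no change at the digits printed from compound 3 to compound 4 (within the scatter).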

Compound 4, largest response reached (Emax), in percent of the reference or control that the assay uses: 79.8%
Compound 4: the middle estimate sits 5.2 percentage points above what was measured, and the stated range covers the measured number.
By their numbers in this assay, from the lowest: compounds 1, 4 and 3 (each within the scatter of the next); then compound 2.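

With the methoxyethyl amide held constant, the only step shown at this end of the molecule reads, in this assay, a number 5.2 percentage points lower from compound 3 to compound 4 (within the scatter). Going by these compounds alone, on a saturated chain carbon bound to an aromatic carbon, 3-chloro-5-fluorophenyl and 3-(trifluoromethyl)phenyl therefore cannot be told apart by maximal response, although the earlier steps, all on the amide side chain, gave no reading for this position. No available data explain why these two aryl groups read alike, and this single pair does not extend to other amide side chains.

It remains open whether the carbamoyl side chain of compound 2, which gives 102%, keeps that response when paired with 3-chloro-5-fluorophenyl, since the compounds shown pair it only with 3-(trifluoromethyl)phenyl. Also open is how far this position tolerates other groups, such as an unsubstituted phenyl, a pyridine ring or a phenyl bearing a carboxylic acid, as the two aryl groups shown are both halogen-bearing phenyl rings.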